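A few compounds are considered here, and "the series" means these few. Any claim that something is new, unique, unknown or untested is made for them only; others in the source may bear on it.

Measured compounds:
compound 1, `CN(C)c1ccc2c(=O)c(C(=O)Nc3cc(F)cc(F)c3)cn(-c3ccc(Cl)c(OCCCCCCC[N+]45CCN(CC4)CC5)c3)c2n1`: 8.08%
compound 2, `CN(C)c1ccc2c(=O)c(C(=O)Nc3cc(F)cc(F)c3)cn(-c3ccc(Cl)c(OCCCCCCC[N+]4(C)CCCC4)c3)c2n1`: 51%
compound 3, `Cc1ccc(-n2cc(C(=O)Nc3cc(F)cc(F)c3)c(=O)c3ccc(N(C)C)nc32)cc1OCCCCCCC[n+]1ccccc1`: 39.7%

All three were tested in an assay on LX2 cells for inhibition of COL1A1 promoter (Homo sapiens), read by a luciferase reporter, with a stated time of 24 h, tested at 20 uM; on this read-out higher numbers stand for a stronger effect at the one concentration tested and lower numbers for a weaker effect. Compound 3 stands second of the three: compound 2 lies above it by a gap beyond the scatter, and compound 1 lies well below it. For the measured compounds named here, the only single-place step on record, a number 42.9 percentage points higher from compound 1 to compound 2 (beyond the scatter), concerns the charged group at the far end of the chain, not the six-membered aromatic ring of carbon only. Compound 4, `CN(C)c1ccc2c(=O)c(C(=O)Nc3cc(F)cc(F)c3)cn(-c3ccc(Cl)c(OCCCCCCC[n+]4ccccc4)c3)c2n1`, differs from compound 3 in a different place: chloro in place of methyl on an aromatic carbon. Going by the values given here, no measured pair differs in exactly this way, so that step gives no direct guide. Chloro is already present in compound 1 and compound 2, but both also carry a different charged end group, so their numbers cannot be read as the effect of chloro alone. With nothing pointing in either direction, no step beyond the scatter is expected, a number 0.3 percentage points higher from compound 3 to compound 4 (within the scatter). Compound 4 is therefore estimated at 40%, with a range from 20% to 60%.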

Compound 4, a percentage reported as inhibition, at one concentration (the size of the read-out at that concentration, not a potency): "not active" (no number reported)
Compound 4 has no reported number here; the estimate stays without a comparison.
By their numbers in this assay, from the lowest: compound 1; then compound 3; then compound 2.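

For the compounds shown here, compound 4 is reported as "not active" with no number, so no step from compound 3 to compound 4 can be read. From the compounds shown here alone, how far chloro in place of methyl shifts the effect stays open. No supporting data bear on this result.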